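This account rests on a few compounds, and the source may have more. Where it says the series, first, only, none or still open, it means among the compounds named here.

Working notes on the series of three measured compounds and one still open. All share a central ring bearing three aryl groups; the read-out is a functional assay on HeLa cells (Homo sapiens) for cytotoxicity, read by CCK-8 assay; on this read-out lower numbers stand for stronger inhibition and higher numbers for weaker inhibition. Compound 1 `Oc1ccc(-c2cc(-c3ccsc3)cc(-c3cccc(O)c3)n2)cc1` gives 2580 nM in this assay. Compound 2 `Oc1cccc(-c2cc(-c3ccccn3)cc(-c3ccccc3O)n2)c1` gives 2020 nM in this assay. For compound 3 `Oc1ccc(-c2cc(-c3ccccn3)cc(-c3ccccc3O)n2)cc1` only a limit of the assay is known, > 50000 nM in this assay, recorded as the limit of > 50000 nM in this assay, at which 1 of the 3 values shown sits. Within the data shown here, the one measured step that can be followed, an at least 24-fold higher number from compound 2 to compound 3 (1.39 log units; beyond the scatter), therefore runs from a number to a limit, and compound 3 stands at the weak end of what the numbers show.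

Compound 4 `Oc1ccc(-c2cc(-c3ccccn3)cc(-c3cccc(O)c3)n2)cc1` is not yet measured. It differs from compound 3 by 3-hydroxyphenyl in place of 2-hydroxyphenyl on an aromatic carbon. Among the measured compounds shown here, no measured step matches this exchange directly; the pair compound 2 and compound 3 exchanges a different hydroxyphenyl, and compound 1 carries the same two hydroxyphenyl groups as compound 4 with a thiophen-3-yl instead of the pyridin-2-yl. Given that compound 1 reaches 2580 nM with that arrangement, compound 4 is expected to return to a measurable number, and the step of an at least 6.2-fold lower number from compound 3 to compound 4 (0.79 log units; beyond the scatter) is estimated to run toward stronger inhibition. Compound 4 is expected at about 8000 nM, within 2000 nM to 50000 nM.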

Compound 4, half-maximal inhibitory concentration: 1930 nM
The estimate for compound 4 lay 4.1-fold (0.62 log units) above the measured number; the measured number lies below the stated range.
By their numbers in this assay, from the lowest: compounds 4, 2 and 1 (each within the scatter of the next). At a limit, above all of these: compound 3.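

On the aromatic carbon next to the ring nitrogen, 3-hydroxyphenyl in place of 2-hydroxyphenyl brings back a measurable number in this assay, with an at least 25-fold lower number from compound 3 to compound 4 (1.41 log units; beyond the scatter), so the size of this step is only a minimum. Compound 3 remains at a limit of the assay: the limit of > 50000 nM in this assay, at which 1 of the 4 values shown sits. The other two exchanges do not separate the compounds, with 4-hydroxyphenyl in place of 2-hydroxyphenyl giving a 1.0-fold lower number from compound 2 to compound 4 (0.02 log units; within the scatter) and pyridin-2-yl in place of thiophen-3-yl giving a 1.3-fold lower number from compound 1 to compound 4 (0.13 log units; within the scatter), so among these four compounds neither 2-hydroxyphenyl, 4-hydroxyphenyl nor pyridin-2-yl alone goes with the loss, which appears only where 2-hydroxyphenyl and 4-hydroxyphenyl occur together in compound 3.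

The compounds shown leave open why that one pairing differs, and whether it would also fall to the limit with thiophen-3-yl in place of pyridin-2-yl. They also leave open whether the hydroxyl itself is needed at this position, since a methoxy group or an amine on the phenyl ring does not appear among them.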